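The compounds below may be only part of what the source reports. "The series", "measured", "known", "first", "only" and "open" are said of these compounds alone.

Measured compounds:

Compound 1, `CC(C(=O)N1C[C@H]2CCC[C@H]2C1)N1CCN(S(=O)(=O)c2ccc(C(C)(C)C)cc2)CC1`: in an ADME assay on HepG2 cells (Homo sapiens) for inhibition, with a stated time of 48 h (a higher number here means that more compound is needed for the effect, a lower number that less compound is needed), compound 1 gives > 40000 nM, which is a limit of the assay rather than a number.

Compound 2, `CCC(C)c1ccc(S(=O)(=O)N2CCN(C(C)C(=O)N3CCCC3)CC2)cc1`: in this assay compound 2 gives > 40000 nM, again a limit of the assay and not a number.

Where compound 2 stands is therefore only bounded: both values shown sit at the limit of > 40000 nM in this assay, at which 2 of the 2 values shown sit, so no order between compound 1 and compound 2 can be drawn, and no step between measured compounds is available in this series.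

Compound 3, `CC(C(=O)N1CCCC1)N1CCN(S(=O)(=O)c2ccc(C(C)(C)CO)cc2)CC1`, is not yet measured. It differs from compound 2 by 1-(hydroxymethyl)-1-methylethyl in place of sec-butyl on an aromatic carbon; in words, 1-(hydroxymethyl)-1-methylethyl in place of sec-butyl on an aromatic carbon. With both measured values at the limit, nothing in the data points to a direction for this change, and the working expectation is no step beyond the scatter, the value most likely remaining at the limit. The expected step is a number no higher from compound 2 to compound 3 (the limit leaves the size open). For compound 3 the estimated value in this assay is 40000 nM, with a range from 15000 nM to 100000 nM.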

Compound 3, half-maximal effective concentration: > 40000 nM
Compound 3 gave a limit, no number (the forecaster's own chance of this, stated with the estimate: 80%); the middle value sits exactly at the limit.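

No step can be read between compound 2 and compound 3 in this assay: with 1-(hydroxymethyl)-1-methylethyl in place of sec-butyl on an aromatic carbon, both compounds remain at a limit of the assay, not a number. The compounds shown leave open how they rank and whether any change on the shared core moves the value, all being bounded only by the same limit: the limit of > 40000 nM in this assay, at which 3 of the 3 values shown sit.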